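Removing the carboxy group from compound 2

This account rests on a few compounds, and the source may have more. Where it says the series, first, only, none or still open, it means among the compounds named here.

In a functional assay (aorta) with Rattus norvegicus as the target (a lower number here means a stronger inhibitor, a higher number a weaker inhibitor), compound 1 (`CC1(C)Oc2ccc(C#N)cc2[C@@H](/N=C(\NC#N)Nc2ccc(C(F)(F)F)cc2)[C@@H]1O`) gives 8100 nM. Compound 2 (`CC1(C)Oc2ccc(C#N)cc2[C@@H](/N=C(\NC#N)Nc2ccc(C(=O)O)cc2)[C@@H]1O`) gives > 100000 nM in this assay, and this is a limit of the assay and not a number. For the measured compounds named here, the one measured step is an at least 12-fold higher number from compound 1 to compound 2 (1.09 log units; beyond the scatter), with carboxy in place of trifluoromethyl on an aromatic carbon, and it is large.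

Compound 3 (`CC1(C)Oc2ccc(C#N)cc2[C@@H](/N=C(\NC#N)Nc2ccc(Cl)c(Cl)c2)[C@@H]1O`) departs from compound 2 at a single place: 3,4-dichlorophenyl in place of 4-carboxyphenyl on an amine nitrogen. It carries 3,4-dichlorophenyl in place of 4-carboxyphenyl on an amine nitrogen. Like compound 1, it has no carboxy group, so the change runs roughly against the measured step, which is the only one that bears on it. That step was made with trifluoromethyl rather than two chlorines, so it is only a loose guide, and the starting point is a limit. A large move towards a lower number, beyond the scatter, is therefore expected, which would place compound 3 near compound 1 at 8100 nM. The expected size is an at least 25-fold lower number from compound 2 to compound 3 (1.39 log units; beyond the scatter). For compound 3 the estimated value is 4000 nM, with an expected range from 800 nM to 20000 nM.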

Compound 3, half-maximal inhibitory concentration: 4600 nM
For compound 3 the middle estimate is 1.2-fold (0.06 log units) below the measured one; low and high end bracket the measured number.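

In this assay, putting 3,4-dichlorophenyl in place of 4-carboxyphenyl on the amine nitrogen gives an at least 21-fold lower number from compound 2 to compound 3 (1.33 log units; beyond the scatter), so the large gap first seen with 4-(trifluoromethyl)phenyl is not confined to that one group. Between the two groups that lack the carboxy, the step is a 1.8-fold lower number from compound 1 to compound 3 (0.25 log units; within the scatter), so 3,4-dichlorophenyl and 4-(trifluoromethyl)phenyl cannot be told apart at this position in this assay. The true size of the step away from compound 2 remains unknown, as the value of compound 2 is a limit of the assay and not a number: the limit of > 100000 nM in this assay, at which 1 of the 3 values shown sits.

The compounds shown leave open whether the carboxy group alone sets compound 2 apart, since only two groups without it are compared at this position, and each of those carries halogen atoms. A plain phenyl, or a phenyl bearing an amide or a methyl ester in place of the carboxy, would show whether the number falls only with trifluoromethyl or chlorine on the ring, or with any group other than the carboxylic acid.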